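The source may report more compounds than this note shows. Statements on the series, on what has been measured and on what is new or still open speak of the compounds shown alone.

Of the compounds shown here, three built on one shared core have been tested in a functional assay on HepG2 cells (Homo sapiens) for cytotoxicity, read by MTT assay, with a stated time of 72 h; a higher number here means a weaker inhibitor, a lower number a stronger inhibitor. Compound 1 `CN1CCN(CCCOc2c(OCc3ccccc3)cc(O)c3c(=O)cc(-c4ccccc4)oc23)CC1` gives 3110 nM. Compound 2 `O=c1cc(-c2ccccc2)oc2c(OCCCCN3CCCC3)c(OCc3ccccc3)cc(O)c12` gives 4660 nM, and compound 3 `CN1CCN(CCCCOc2c(OCc3ccccc3)cc(O)c3c(=O)cc(-c4ccccc4)oc23)CC1` gives 1500 nM. The lowest of the three numbers belongs to compound 3: a 2.1-fold lower number from compound 1 to compound 3 (0.32 log units; beyond the scatter), and a 3.1-fold lower number from compound 2 to compound 3 (0.49 log units; beyond the scatter). Compound 1 and compound 2 sit close together, since a 1.5-fold higher number from compound 1 to compound 2 (0.18 log units; within the scatter).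

Compound 4 `CN1CCN(CCCCOc2c(OCc3cccs3)cc(O)c3c(=O)cc(-c4ccccc4)oc23)CC1` has not yet been measured. It differs from compound 3 in one place: thiophen-2-yl in place of phenyl on a saturated chain carbon bound to an oxygen on an aromatic ring. None of the three measured steps touches this part of the molecule. Each of them either swaps pyrrolidin-1-yl for 4-methylpiperazin-1-yl or lengthens the saturated chain that carries that ring, while the benzyloxy group stays the same throughout. Within the data shown here, there is therefore no measured step that bears directly on the change from benzyloxy to (thiophen-2-yl)methoxy, and no ground in these data for expecting a step in this assay beyond the scatter in either direction. Compound 4 is therefore expected to give about 1500 nM, with a plausible range from 600 nM to 4000 nM. For compound 4 the expected step is no change at the digits printed from compound 3 to compound 4 (within the scatter), within the scatter.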

Compound 4, half-maximal inhibitory concentration: 4560 nM
For compound 4 the middle estimate is 3.0-fold (0.48 log units) below the measured one, outside the stated range (above it).
By their numbers in this assay, from the lowest: compound 3; then compounds 1, 4 and 2 (each within the scatter of the next).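

Swapping phenyl for thiophen-2-yl on a saturated chain carbon bound to an oxygen on an aromatic ring gives, in this assay, a 3.0-fold higher number from compound 3 to compound 4 (0.48 log units; beyond the scatter), so compound 4 is the weaker inhibitor of this pair. The earlier compounds shown here varied only the amine ring and the length of the chain that carries it, with benzyloxy held constant, so they could not show that this other end of the molecule also affects the result; this pair shows that, with the amine and chain of compound 3, the two aromatic rings are not interchangeable. The swap replaces a six-membered aromatic ring of carbon only with a five-membered aromatic ring with one sulfur, but no measurement available here explains the higher number.

As far as these compounds go, it remains open whether the shift follows the sulfur atom, the smaller ring, or the particular attachment of the ring, which furan-2-yl, thiophen-3-yl or pyridin-2-yl groups in the same place could help separate. Also open, from the compounds shown here alone, is whether thiophen-2-yl would produce a similar step alongside the shorter chain of compound 1 or the pyrrolidin-1-yl ring of compound 2.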